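This account rests on a few compounds, and the source may have more. Where it says the series, first, only, none or still open, it means among the compounds named here.

In a functional assay on A549 cells (Homo sapiens) for antiproliferative activity, read by MTT assay, with a stated time of 72 h (on this read-out higher numbers stand for weaker inhibition and lower numbers for stronger inhibition), compound 1 `Cc1ccc(SC(=S)N2CCN(C(=O)OC(C)(C)C)CC2)cc1` gives 2110 nM and compound 2 `CC(C)(C)OC(=O)N1CCN(C(=S)Sc2ccc(F)cc2)CC1` gives 1560 nM. Going by the values given here, these are the only two numbers so far, and they lie within the usual scatter of each other, so compound 2 cannot be ranked ahead of compound 1. Compound 3 `CC(C)(C)OC(=O)N1CCN(C(=S)Sc2ccc(Cl)cc2)CC1` differs from compound 2 in one place: chloro in place of fluoro on an aromatic carbon. In words, it carries chloro in place of fluoro on an aromatic carbon, para to a large group. Among the compounds with values here, the one measured step that bears on this swap is a 1.4-fold lower number from compound 1 to compound 2 (0.13 log units; within the scatter), with fluoro in place of methyl on an aromatic carbon. That step stays within the scatter, so no step beyond the scatter is expected in this assay, and no direction can be favoured. The expected change is a 1.0-fold higher number from compound 2 to compound 3 (0.01 log units; within the scatter). For compound 3 the estimated value is 1600 nM, with an expected range from 800 nM to 3200 nM.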

Compound 3, half-maximal inhibitory concentration: 1070 nM
Compound 3: the middle estimate sits 1.5-fold (0.17 log units) above what was measured; the range from low to high includes it.
By their numbers in this assay, from the lowest: compounds 3, 2 and 1 (each within the scatter of the next).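

In this assay, the change from fluoro to chloro on the aromatic carbon para to a large group gives a 1.5-fold lower number from compound 2 to compound 3 (0.16 log units; within the scatter), and the change from methyl to chloro at the same place gives a 2.0-fold lower number from compound 1 to compound 3 (0.29 log units; within the scatter), so both new steps stay within the scatter. Going by these compounds alone, with a third group now measured at this place, methyl, fluoro and chloro all give numbers that cannot be told apart, whereas the earlier compounds offered only a single comparison between two groups. No measurement is available here that could explain these results.

Still open, going by these compounds, is whether a group of a different kind at this place, such as an amine, a carboxylic acid or a longer chain, would move the number beyond the scatter. Also open, on these data alone, is whether chloro would behave the same way at another place on the ring.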